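The source may report more compounds than this note shows. Statements on the series, on what has been measured and on what is new or still open speak of the compounds shown alone.

Of the compounds shown here, three sharing one core have been tested in an ADME assay on MCF-10A cells (Homo sapiens) for cytotoxicity, read by MTT assay, with a stated time of 24 h; a higher number here means a weaker inhibitor, a lower number a stronger inhibitor. Compound 1, `FC(F)(F)Oc1ccc(-c2cc(COc3ccccc3-c3nc4ccccc4s3)on2)cc1`, gives 43900 nM. Compound 2, `COc1cc(-c2cc(COc3ccccc3-c3nc4ccccc4s3)on2)cc(OC)c1OC`, gives 42900 nM. Compound 3, `c1ccc(-n2cc(COc3ccccc3-c3nc4ccccc4s3)nn2)cc1`, gives 36400 nM. Among these three numbers compound 1 stands highest, but the gap to compound 2 and the gap to compound 3 both fall within the usual scatter of repeated measurements, so the three values cannot be told apart with confidence; all three compounds behave alike in this assay.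

Compound 4, `Fc1ccccc1-c1cc(COc2ccccc2-c2nc3ccccc3s2)on1`, has not yet been measured. It differs from compound 1 in one place: 2-fluorophenyl in place of 4-(trifluoromethoxy)phenyl on an aromatic carbon. Among the measured compounds shown here, no measured pair in this set differs in exactly one group, so there is no comparable step to lean on. What the three measured compounds do show is that changing the group on that position of the shared core, from 4-(trifluoromethoxy)phenyl to 3,4,5-trimethoxyphenyl or to a phenyl on a different five-membered ring, left the numbers within scatter of one another. On that basis, the step from compound 1 to compound 4 is expected to be small, a 1.1-fold lower number from compound 1 to compound 4 (0.04 log units; within the scatter), with no clear direction beyond the scatter. Compound 4 is therefore estimated at 40000 nM, within a range from 20000 nM to 80000 nM.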

Compound 4, half-maximal inhibitory concentration: 42500 nM
For compound 4 the middle estimate is 1.1-fold (0.03 log units) below the measured one, within the range that was stated.
By their numbers in this assay, from the lowest: compounds 3, 4, 2 and 1 (each within the scatter of the next).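

Among the compounds shown here, this pair is the first in the set that differs in exactly one place, so the group on the aromatic carbon next to the ring nitrogen can now be read directly. In this assay, 2-fluorophenyl in place of 4-(trifluoromethoxy)phenyl gives a 1.0-fold lower number from compound 1 to compound 4 (0.01 log units; within the scatter), even though the group goes from 11 heavy atoms to 7 and from 1 hydrogen-bond acceptor to 0. For this one change, then, a clearly smaller group without the acceptor leaves the two compounds indistinguishable in this read-out, and nothing available here bears on why that is so.

Every group shown at this position is a six-membered aromatic ring of carbon, so it remains open what an amine, a carboxylic acid or a longer alkyl chain would do in that place. A plain phenyl on the same five-membered ring would show whether the substituents on that ring matter at all, or whether the number stays put across all such groups.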